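The source may report more compounds than this note shows. Statements on the series, on what has been measured and on what is new or still open speak of the compounds shown alone.

In a functional assay on GBM1 cells (Homo sapiens) for antiproliferative activity, read by WST assay, with a stated time of 72 h (a lower number here means a stronger inhibitor, a higher number a weaker inhibitor), compound 1 (`O=C(Nc1ccc(C(F)(F)F)cc1)Nc1cc2ncncc2cc1OCc1cccc(F)c1`) gives 3800 nM. That number lies within the scatter of compound 3 (`O=C(Nc1ccc(Cl)c(Cl)c1)Nc1cc2ncncc2cc1OCc1cccc(F)c1`), which gives 2100 nM, while compound 2 (`O=C(Nc1cc2ncncc2cc1OCc1ccc(Cl)cc1)Nc1cccc2ccccc12`) gives 7900 nM, the highest of the three numbers. Compound 4 (`O=C(Nc1ccc(C(F)(F)F)cc1)Nc1cc2ncncc2cc1OCc1cccc(Cl)c1`) departs from compound 1 in one place: chloro in place of fluoro on an aromatic carbon. Among the measured compounds shown here, the only measured step between compounds that differ in one place, a 1.8-fold lower number from compound 1 to compound 3 (0.26 log units; within the scatter), is small and falls on an amide-type nitrogen, not on the aromatic carbon changed in compound 4. Compound 2 differs from compound 1 in more than one place and isolates nothing here. No measurement tests this exchange directly, so no step beyond the scatter is expected in this assay. The expected result is a 1.2-fold lower number from compound 1 to compound 4 (0.06 log units; within the scatter). Compound 4 is estimated at 3300 nM, with an expected range from 1500 nM to 7200 nM.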

Compound 4, half-maximal inhibitory concentration: 3400 nM
Beside the measured number, compound 4's estimate is 1.0-fold (0.01 log units) below it; low and high end bracket the measured number.
By their numbers in this assay, from the lowest: compounds 3, 4 and 1 (each within the scatter of the next); then compound 2.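

Among the compounds shown here, the step of a 1.1-fold lower number from compound 1 to compound 4 (0.05 log units; within the scatter) in this assay gives the first direct reading at this aromatic carbon of the benzyl group: chloro in place of fluoro leaves the number within the scatter. For the compounds shown here, the one step available before this fell on an amide-type nitrogen and did not touch this position, so the earlier compounds said nothing about the exchange of 3-fluorobenzyl for 3-chlorobenzyl. No supporting evidence is available to account for this result.

The compounds shown leave open whether a bromo, methoxy, amine or carboxylic acid group on this same carbon would move the number beyond the scatter. They also leave open whether the exchange reads the same when the 3,4-dichlorophenyl group of compound 3 stands on the amide-type nitrogen.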